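The source may report more compounds than this note shows. Statements on the series, on what has been measured and on what is new or still open speak of the compounds shown alone.

Compound 1, `CCOC(=O)c1c(-c2c(Cl)c3ccccc3oc2=O)nn(-c2ccccc2)c1C(=O)OCC`, gives 34000 nM in a functional assay on A549 cells (Homo sapiens) for cytotoxicity, read by MTT assay, with a stated time of 48 h; a higher number here means a weaker inhibitor, a lower number a stronger inhibitor.
Compound 2, `CCOC(=O)c1c(-c2c(Cl)c3ccccc3oc2=O)nn(-c2ccc(Br)cc2)c1C(=O)OCC`, gives 30000 nM in this assay.

For the measured compounds named here, of these two numbers, the one for compound 1 is the higher, but the step of a 1.1-fold lower number from compound 1 to compound 2 (0.05 log units; within the scatter) lies within the scatter, so the two compounds are not separated by the data. Compound 3, `CCOC(=O)c1c(-c2c(Cl)c3cc(C)ccc3oc2=O)nn(-c2ccccc2)c1C(=O)OCC`, has not yet been measured. It differs from compound 1 by methyl in place of hydrogen on an aromatic carbon. Going by the values given here, no measured step concerns that fused ring; the only step available, a 1.1-fold lower number from compound 1 to compound 2 (0.05 log units; within the scatter), concerns a bromo in place of hydrogen on an aromatic carbon elsewhere in the molecule and stayed within the scatter. There is therefore no basis for expecting a shift in this assay beyond the scatter in either direction, and compound 3 is expected to sit close to compound 1. Compound 3 is estimated at 30000 nM, within a range from 12000 nM to 80000 nM, which means an expected step of a 1.1-fold lower number from compound 1 to compound 3 (0.05 log units; within the scatter).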

Compound 3, half-maximal inhibitory concentration: 108000 nM
The estimate for compound 3 lay 3.6-fold (0.56 log units) below the measured number; the measured number lies above the stated range.
By their numbers in this assay, from the lowest: compounds 2 and 1 (each within the scatter of the next); then compound 3.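

For the compounds shown here, the methyl group gives the first step in this assay that lies beyond the scatter, a 3.2-fold higher number from compound 1 to compound 3 (0.50 log units; beyond the scatter), and this modest step runs toward a weaker inhibitor. This aromatic carbon, in a six-membered aromatic ring of carbon only that is part of a fused system of two rings, is thus a place where one added carbon separates two compounds, which the bromo step a 1.1-fold lower number from compound 1 to compound 2 (0.05 log units; within the scatter) elsewhere in the molecule did not do. Nothing measured here accounts for this shift.

With a single group at this carbon, the compounds shown leave open whether a longer chain, an amine or a carboxylic acid there would move the number the same way or further. They also leave open whether the methyl step would hold alongside the bromo group of compound 2.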